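Triazole in place of the nitrile on the ether chain

A few compounds are considered here, and "the series" means these few. Any claim that something is new, unique, unknown or untested is made for them only; others in the source may bear on it.

Compound 1 `CCc1cc(C(C)=O)c(O)cc1OCCCCCCC(C)(C)C#N` has been tested in an assay on isolated protein for inhibition of leukotriene B4 receptor 1 (Homo sapiens), tested at 10 uM (on this read-out lower numbers stand for less inhibition and higher numbers for more inhibition at the one concentration tested (going by the name of the read-out)), and gives 65% there. For the measured compounds named here, the only other number in hand is from compound 2 `C=CCCCCOc1cc(O)c(C(C)=O)cc1CC=C`, which in this assay gives 73%. Of the two numbers, compound 1 is the lower, but its gap to compound 2 lies within the scatter of repeated measurements, so the two values cannot be ordered and no trend in the series can be read from them.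

Compound 3 `CCc1cc(C(C)=O)c(O)cc1OCCCCCn1cncn1` has not yet been measured in this assay. Its difference from compound 1 is 1H-1,2,4-triazol-1-yl in place of 2-cyano-2-methylpropyl on a saturated chain carbon, five bonds along the chain from an oxygen on an aromatic ring. The rest of the shared core, including the acetyl and the hydroxy group and the ether oxygen, is kept.

Going by the values given here, no step between measured compounds is available that would show what such a swap does. The expectation is therefore a step within the scatter, in either direction, given as a number 7 percentage points lower from compound 1 to compound 3 (within the scatter) from compound 1 to compound 3. Compound 3 is estimated to give 58% in this assay, with a range from 30% to 82%.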

Compound 3, a percentage reported as inhibition, at one concentration (the size of the read-out at that concentration, not a potency): 82%
Estimate against measurement, compound 3: 24 percentage points below, and the stated range covers the measured number.
By their numbers in this assay, from the lowest: compounds 1, 2 and 3 (each within the scatter of the next, the first and the last beyond it).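

In this assay, for the compounds shown here, the exchange of 2-cyano-2-methylpropyl for 1H-1,2,4-triazol-1-yl gives a number 17 percentage points higher from compound 1 to compound 3 (beyond the scatter), the first step that can be read at all. This shows that the number responds to the group carried on a saturated chain carbon, five bonds along the chain from an oxygen on an aromatic ring, and that a five-membered aromatic ring with 3 hetero atoms is accepted there in place of a nitrile-bearing group with no ring. No measurement in hand speaks to why the number rises.

This single step cannot separate the contribution of the triazole from that of losing the nitrile, and a reading at one concentration is not a potency. An imidazol-1-yl ring, a carboxylic acid or a dimethylamino group at the same place, or a longer chain carrying the same triazole, would show whether the rise is specific to the 1H-1,2,4-triazol-1-yl group or holds more widely for other groups at this chain end.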